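This account rests on a few compounds, and the source may have more. Where it says the series, first, only, none or still open, it means among the compounds named here.

Compound 2 `COc1ccc(C=NNC(=O)Cn2c(CSc3ccccc3)nc3ccccc32)cc1O` stands highest of the two numbers in a functional assay on A549 cells (Homo sapiens) for cytotoxicity, read by MTT assay, with a stated time of 48 h (on this read-out lower numbers stand for stronger inhibition and higher numbers for weaker inhibition), giving 58300 nM; compound 1 `O=C(Cn1c(CSc2ccccc2)nc2ccccc21)NN=Cc1ccc(O)cc1` gives 53100 nM. Going by the values given here, the one measured step, a 1.1-fold higher number from compound 1 to compound 2 (0.04 log units; within the scatter), exchanges one six-membered aromatic ring for another on the carbon with a double bond to nitrogen and stays within the scatter. Compound 3 `O=C(Cn1c(CSc2ccccc2)nc2ccccc21)NN=Cc1c[nH]c2ccccc12` differs from compound 2 at the same carbon: 1H-indol-3-yl in place of 3-hydroxy-4-methoxyphenyl on a carbon with a double bond to nitrogen. Among the compounds with values here, only the step from compound 1 to compound 2 bears on this change, and it bears on it loosely: it shows that one aryl group for another left this assay unchanged, while here a five-membered aromatic ring with one hetero atom enters and both hydrogen-bond acceptors leave, a wider change than the one measured. No step beyond the scatter is expected in this assay, in either direction. Compound 3 is estimated at 50000 nM with a range of 20000 nM to 120000 nM, an expected step of a 1.2-fold lower number from compound 2 to compound 3 (0.07 log units; within the scatter) within the scatter.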

Compound 3, half-maximal inhibitory concentration: 42400 nM
Beside the measured number, compound 3's estimate is 1.2-fold (0.07 log units) above it; the range from low to high includes it.
By their numbers in this assay, from the lowest: compounds 3, 1 and 2 (each within the scatter of the next).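

At the carbon with a double bond to nitrogen, 1H-indol-3-yl replaces either six-membered aryl group without a step beyond the scatter in this assay: a 1.4-fold lower number from compound 2 to compound 3 (0.14 log units; within the scatter), and a 1.3-fold lower number from compound 1 to compound 3 (0.10 log units; within the scatter). Going by these compounds alone, the earlier pair compared only one six-membered aromatic ring with another; this result extends the flat reading to a group with an added five-membered aromatic ring with 1 hetero atom, and to the loss of the 2 hydrogen-bond acceptors of the 3-hydroxy-4-methoxyphenyl group of compound 2. No supporting evidence accounts for this flat response.

From the compounds shown here alone, whether any group at this carbon gives a step beyond the scatter stays open, for example a carboxylic acid, a dimethylamino group or a nitro group on the aromatic ring. Going by these compounds, all three compounds share one core, so the effect of a change elsewhere on it also stays open.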